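The compounds below may be only part of what the source reports. "The series", "measured", "known", "first", "only" and "open" are said of these compounds alone.

Of the compounds shown here, three built on a shared core have been measured in an assay on HEK293 cells for agonist activity at transient receptor potential cation channel subfamily M member 8 (Homo sapiens), read by fluorescence and calcium flux, with a stated time of 15 min; on this read-out higher numbers stand for an effect only at larger amounts of compound and lower numbers for an effect already at smaller amounts. Compound 2 `CCN(Cc1ccco1)C(=O)COc1ccc(C)cc1` gives 489 nM, the highest of the three numbers. Compound 1 `CCN(Cc1cccs1)C(=O)COc1ccc(C(F)(F)F)cc1` gives 236 nM, and compound 3 `CON(Cc1cccs1)C(=O)COc1ccc(C)cc1` gives 10 nM; both numbers lie below that of compound 2, the gap to compound 3 being much the wider. Compound 4 `CCN(Cc1nccs1)C(=O)COc1ccc(C)cc1` has not yet been measured. It differs from compound 2 in a single place: 1,3-thiazol-2-yl in place of furan-2-yl on a saturated chain carbon bound to an amide-type nitrogen. No measured pair isolates this particular exchange, so nothing shown here tells how it acts. In this assay the change is expected to bring a 1.2-fold lower number from compound 2 to compound 4 (0.09 log units; within the scatter), with no firm direction and quite possibly within the scatter. Compound 4 is therefore expected to give about 400 nM, within a range from 120 nM to 1300 nM.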

Compound 4, half-maximal effective concentration: 3060 nM
The estimate for compound 4 lay 7.7-fold (0.88 log units) below the measured number; measured number above the stated range.
By their numbers in this assay, from the lowest: compound 3; then compound 1; then compound 2; then compound 4.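

In this assay, the exchange of furan-2-yl for 1,3-thiazol-2-yl on a saturated chain carbon bound to an amide-type nitrogen brings a 6.3-fold higher number from compound 2 to compound 4 (0.80 log units; beyond the scatter). This position therefore does not treat these two five-membered aromatic rings as interchangeable, although both have the same number of heavy atoms. Nothing available explains why the number rises at this position.

As far as these compounds go, whether a phenyl or pyridin-2-yl ring here would give a lower or higher number than furan-2-yl remains open. So does whether this exchange would have a similar effect on compound 3.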